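The source may report more compounds than this note shows. Statements on the series, on what has been measured and on what is new or still open speak of the compounds shown alone.

Measured in an ADME assay on HEL cells (Homo sapiens) for cytotoxicity, with a stated time of 3 days; on this read-out higher numbers stand for lower toxicity in this test and lower numbers for higher toxicity in this test:
Compound 1 `CCCCCc1ccc(CCc2cc3cn([C@H]4C[C@H](O)[C@@H](CO)O4)c(=O)nc3o2)cc1`: > 470000 nM
Compound 2 `CCCCCc1ccc(-c2cc3cn([C@H]4C[C@H](O)[C@@H](CO)O4)c(=O)nc3o2)cn1`: > 50000 nM

Compound 1 gives only a limit (> 470000 nM) and not a number. Compound 2 also gives only a limit (> 50000 nM) and no number. The step to follow leads to compound 3 `O=c1nc2oc(CCc3ccccc3)cc2cn1[C@H]1C[C@H](O)[C@@H](CO)O1`, which has hydrogen in place of pentyl on an aromatic carbon, para to a large group (hydrogen in place of pentyl on an aromatic carbon). Among the compounds with values here, no measured pair shows what such a change does in this assay, so any expectation here is loose. A small move toward lower numbers, close to the usual scatter, is expected, and the reading may again be only a limit. The expected change is an at least 2.3-fold lower number from compound 1 to compound 3 (0.37 log units; beyond the scatter) in this assay. For compound 3 the estimated value is 200000 nM (expected range 40000 nM to 500000 nM).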

Compound 3, half-maximal cytotoxic concentration: > 560000 nM
Compound 3: only a limit was reported (the forecaster's own chance of this, stated with the estimate: 75%); at least 2.8-fold (0.44 log units) between middle value and limit.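

In this assay, within the data shown here, compound 1 and compound 3 are each reported only as a limit, so no step between them can be read. The compounds shown leave open what hydrogen in place of pentyl does to this read-out, and where any actual half-maximal cytotoxic concentration lies.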